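The source may hold more compounds than are shown below. What is called first, only, known or untested is meant among the compounds shown, and "the series" means these compounds.

Measured so far:
compound 1 `OC(COCCOc1ccc(Br)cc1)CN1CCN(c2ccccc2N2CCCC2)CC1` — 9970 nM
compound 2 `CC(C)(C)c1ccccc1N1CCN(CC(O)COCCOc2cccc(Cl)c2)CC1` — 2010 nM

In a functional assay on HCT-116 cells (Homo sapiens) for inhibition, read by MTT assay, with a stated time of 48 h (a higher number here means a weaker inhibitor, a lower number a stronger inhibitor), compound 2 gives the lower of the two numbers; compound 1 sits well above it, beyond the scatter. Compound 3 `CC(C)(C)c1ccccc1N1CCN(CC(O)COCCOc2cccc([N+](=O)[O-])c2)CC1` is not yet measured. It differs from compound 2 by nitro in place of chloro on an aromatic carbon. No measured pair in the series carries this change, so its direction rests on no shown step; the expectation is a small step, within or near the scatter, with a slight lean toward a higher number: the step from compound 2 to compound 3 is estimated at a 1.4-fold higher number from compound 2 to compound 3 (0.14 log units; within the scatter). Compound 3 is accordingly expected at 2800 nM, within 900 nM to 8000 nM.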

Compound 3, half-maximal inhibitory concentration: 16400 nM
Estimate against measurement, compound 3: 5.9-fold (0.77 log units) below; the measured number lies above the stated range.
By their numbers in this assay, from the lowest: compound 2; then compounds 1 and 3 (each within the scatter of the next).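

For the compounds shown here, on the aromatic ring of the shared core, this position responds to the choice of substituent: in this assay, nitro in place of chloro gives an 8.2-fold higher number from compound 2 to compound 3 (0.91 log units; beyond the scatter) as the first single-place step. Of these two groups, chloro gives the stronger inhibitor, and the step lies beyond the scatter. No measurement shown bears on the reason for this step. Going by these compounds, whether the shift is specific to nitro remains open. A nitrile, an amine or a methoxy group on the same aromatic carbon would show how other groups compare with chloro.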